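Acid to isopropylamide on a thiazole-bearing agonist of the receptor

The source may hold more compounds than are shown below. What is called first, only, known or untested is meant among the compounds shown, and "the series" means these compounds.

Compound 1: `Cc1nc(-c2ccc(C(F)(F)F)cc2)sc1CNc1ccc(CCC(=O)O)cc1`, 67.6 nM
Compound 2: `O=C(O)CCCc1ccc(NCc2cccc(Oc3ccccc3)c2)cc1`, 1120 nM
Compound 3: `CNC(=O)CCc1ccc(NCc2cccc(Oc3ccccc3)c2)cc1`, 49 nM

Three compounds were measured in a functional assay on CHO cells for agonist activity at Free fatty acid receptor 1 (Homo sapiens); a lower number here means that less compound is needed, a higher number that more compound is needed for the effect. Compound 1 gives 67.6 nM, which places it second highest of the three numbers; compound 3 lies closest to it, within the scatter, while compound 2 stands furthest away, beyond it. The piece follows compound 1 to the unmeasured compound 4, `Cc1nc(-c2ccc(C(F)(F)F)cc2)sc1CNc1ccc(CCC(=O)NC(C)C)cc1`. The change is isopropylamino in place of hydroxy on a carbonyl carbon.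

Among the measured compounds shown here, one measured step bears directly on this change: the replacement of the acid by an amide within the other pair, a 23-fold lower number from compound 2 to compound 3 (1.36 log units; beyond the scatter). That step moved the number strongly downward. The present change also replaces the hydroxy of the acid by an amine, though with isopropylamino rather than methylamino, so the same direction is expected, perhaps with a somewhat smaller size given the different amine. Compound 4 is therefore expected to show a step of a 6.8-fold lower number from compound 1 to compound 4 (0.83 log units; beyond the scatter) in this assay. The estimate for compound 4 is 10 nM, with a range from 3 nM to 40 nM.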

Compound 4, half-maximal effective concentration: 100 nM
Compound 4: middle estimate off by 10-fold (1.00 log units), on the low side; measured number outside the range, above it.
By their numbers in this assay, from the lowest: compounds 3, 1 and 4 (each within the scatter of the next, the first and the last beyond it); then compound 2.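

In this assay, the step of a 1.5-fold higher number from compound 1 to compound 4 (0.17 log units; within the scatter) shows that on this core isopropylamino can take the place of hydroxy on the carbonyl carbon without a change that can be read beyond the scatter. The large step of a 23-fold lower number from compound 2 to compound 3 (1.36 log units; beyond the scatter) therefore does not carry over to this pair, so replacing an acid by an amide has no single outcome across the compounds shown; those two steps differ in the entering group, the chain and the rest of the molecule. No available evidence explains why the two steps differ.

The compounds shown leave open how methylcarbamoyl would read on the core of compound 1, and whether a primary amide would behave like 2-(isopropylcarbamoyl)ethyl there. From the compounds shown here alone, a longer chain carrying the carboxylic acid on that core also remains open.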